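This account rests on a few compounds, and the source may have more. Where it says the series, first, only, none or still open, it means among the compounds named here.

Measured compounds:

Compound 1, `COc1ccccc1C(=O)Nc1nnc(SCC(=O)Nc2ccc(C)cn2)s1`. In a functional assay on HeLa cells (Homo sapiens) for antiproliferative activity, read by MTT assay, with a stated time of 48 h (on this read-out lower numbers stand for stronger inhibition and higher numbers for weaker inhibition), compound 1 gives > 80000 nM, which is a limit of the assay and not a number.

Compound 2, `O=C(CSc1nnc(NC(=O)CCCl)s1)Nc1ccc(Br)cn1`. In this assay compound 2 gives 5300 nM.

Compound 3, `O=C(CCl)Nc1ccc(SCC(=O)Nc2ccc(Cl)cn2)cc1`. In this assay compound 3 gives 2500 nM.

Of the two numbers that are known, compound 3 has the lowest, which on this read-out means the stronger inhibition of cell growth; the number of compound 2 is higher, and the gap between the two lies beyond the scatter of repeated measurements. Compound 1 adds no number to the comparison, since its result is a limit only (the limit of > 80000 nM in this assay, at which 1 of the 3 values shown sits).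

Compound 4, `O=C(CCl)Nc1ccc(SCC(=O)Nc2ccc(Cl)cc2)cc1`, is the next compound to be measured. Compared with compound 3 the change is small in the count of atoms: 4-chlorophenyl in place of 5-chloropyridin-2-yl on an amide-type nitrogen. The ring that carries the chlorine keeps its size and its chlorine, but the nitrogen in that ring is gone.

Among the measured compounds shown here, no pair among the measured compounds differs in only this one place, so the size of this step has no precedent here. The expectation is therefore a modest step, within or close to the scatter. Compound 4 is expected to give 3500 nM in this assay, in a range from 900 nM to 14000 nM. That estimate means an expected step of a 1.4-fold higher number from compound 3 to compound 4 (0.15 log units; within the scatter).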

Compound 4, half-maximal inhibitory concentration: > 80000 nM
Compound 4 was reported as a limit (the forecaster's own chance of this, stated with the estimate: 10%); middle value at least 22-fold (1.35 log units) from the limit.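

Among the compounds shown here, the two compounds differ in one place only, and it is the first such pair here: on the amide-type nitrogen, 4-chlorophenyl stands in place of 5-chloropyridin-2-yl, which gives an at least 32-fold higher number from compound 3 to compound 4 (1.50 log units; beyond the scatter) in this assay. The ring size and the chlorine stay the same, so in this pair the loss of measurable inhibition of cell growth goes with the replacement of the ring nitrogen by carbon, a far larger effect than the small change in atoms would suggest, though this one pair cannot show how general it is. The result for compound 4 is a limit of the assay and not a number, so the true size of the step stays unknown, and this compound is not alone in sitting there: the limit of > 80000 nM in this assay, at which 2 of the 4 values shown sit.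

The compounds shown leave open whether a ring with a further nitrogen, such as a pyrimidine, would keep or improve the inhibition seen with compound 3. They also leave open whether the chlorine on the pyridine ring can give way to another group, such as a methoxy group or a fluorine, without the same loss.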